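Does a chloro group wake an inactive biaryl?

The compounds below may be only part of what the source reports. "The series", "measured", "known", "first", "only" and "open" are said of these compounds alone.

Measured in a functional assay on Raji cells (Homo sapiens) for cytotoxicity, with a stated time of 72 h (a higher number here means that more compound is needed for the effect, a lower number that less compound is needed), so far:
- compound 1 `C=C[C@@](C)(/C=C/c1ccc(Nc2cc(F)cc(F)c2)cc1)CCC=C(C)C` gives > 26000 nM (a limit)
- compound 2 `C=C[C@@](C)(/C=C/c1ccc(Nc2ccc(Cl)c(Cl)c2)cc1)CCC=C(C)C` gives > 26000 nM (a limit)
- compound 3 `C=C[C@@](C)(/C=C/c1ccc(-c2ccccc2)cc1)CCC=C(C)C` gives > 26000 nM (a limit)

Compound 3 stands at > 26000 nM in this assay, which is a limit and not a number. Among the compounds with values here, the same holds across the set, as the limit of > 26000 nM in this assay, at which 3 of the 3 values shown sit, shows, so no measured compound has yet given a number to rank it by.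

Compound 4 `C=C[C@@](C)(/C=C/c1ccc(-c2ccc(Cl)cc2)cc1)CCC=C(C)C` brings one change to compound 3, chloro in place of hydrogen on an aromatic carbon, para to a large group (chloro in place of hydrogen on an aromatic carbon), or phenyl to 4-chlorophenyl.

Within the data shown here, three measured steps bear on this change, though only loosely. They are a step that the two limits leave unreadable from compound 1 to compound 2, then a step that the two limits leave unreadable from compound 1 to compound 3, and finally a step that the two limits leave unreadable from compound 2 to compound 3. None has a readable size, so none gives a direction.

Compound 2, with its 3,4-dichlorophenyl group, gives > 26000 nM, also a limit.

The expected step is a number no higher from compound 3 to compound 4 (the limit leaves the size open), with no size beyond the scatter and no set direction.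

For compound 4 the estimated value is 26000 nM, with an expected range from 13000 nM to 40000 nM, and a further limit is the likeliest report.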

Compound 4, half-maximal effective concentration: > 26000 nM
Compound 4 ended at the assay's limit; the forecaster's own chance of this, stated with the estimate: 75%; the middle value sits exactly at the limit.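

In this assay compound 4 gives > 26000 nM, which is a limit. Its steps from compound 1, compound 2 and compound 3 cannot be read. The compounds shown leave open how any of them ranks, as none has yet given a number: the limit of > 26000 nM in this assay, at which 4 of the 4 values shown sit.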